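A few compounds are considered here, and "the series" means these few. Any claim that something is new, unique, unknown or untested is made for them only; others in the source may bear on it.

The series is characterised in an assay on HEK293 cells for displacement of a labelled ligand from NPC1-like intracellular cholesterol transporter 1 (Homo sapiens); on this read-out higher numbers stand for weaker inhibition and lower numbers for stronger inhibition. Compound 1, of structure `O=C(CN1CN(c2ccccc2)C2(CCN(C(=O)c3ccc(C4CCCCC4)cc3)CC2)C1=O)NCCO`, gives in this assay 2000 nM. For the measured compounds named here, compound 2, of structure `CC(C)(C)c1ccc(C(=O)N2CCC3(CC2)C(=O)N(CC(=O)NCCCN)CN3c2ccccc2)cc1`, gives in this assay 4200 nM, the higher of the two numbers measured so far; the gap to compound 1 lies beyond the usual scatter of repeated measurements. Going by the values given here, no step between these two measured compounds is counted, so only their two values can be compared.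

Compound 3, of structure `CC1CCCN(C(=O)CN2CN(c3ccccc3)C3(CCN(C(=O)c4ccc(C(C)(C)C)cc4)CC3)C2=O)C1`, has not yet been measured in this assay. It differs from compound 2 in one place: 3-methylpiperidin-1-yl in place of (3-aminopropyl)amino on a carbonyl carbon. The group that leaves carries two hydrogen-bond donors and one acceptor on an open chain; the group that enters is a six-membered non-aromatic ring with one hetero atom and no donors or acceptors.

Among the compounds with values here, with no measured step of this kind available, the direction of the change can only be guessed. Compound 3 is expected to give in this assay a number of the same order as compound 2, with a step of a 1.4-fold lower number from compound 2 to compound 3 (0.15 log units; within the scatter) that is expected to be small and not clearly beyond the scatter. The estimate for compound 3 in this assay is 3000 nM, with a range from 800 nM to 12000 nM.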

Compound 3, half-maximal inhibitory concentration: 12000 nM
Beside the measured number, compound 3's estimate is 4.0-fold (0.60 log units) below it, and the stated range covers the measured number.
By their numbers in this assay, from the lowest: compound 1; then compound 2; then compound 3.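

At this position on the carbonyl carbon, the group matters in this assay: replacing (3-aminopropyl)amino with 3-methylpiperidin-1-yl gives a 2.9-fold higher number from compound 2 to compound 3 (0.46 log units; beyond the scatter) and therefore weaker inhibition. In this one pair, the open chain with hydrogen-bond donors goes with the stronger inhibition and the larger ring without donors or acceptors with the weaker, but the exchange alters the chain, the ring count and the donor count at once, so the pair does not separate these changes. No measurement shown here accounts for the step.

The compounds shown leave open whether the terminal amine, the amide hydrogen or the methyl on the ring is tied to the difference, since no compound changes only one of these features. On these data alone, it also remains open how an unsubstituted piperidin-1-yl, a morpholin-4-yl ring or a carboxylic acid at the end of the chain would read at this position.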